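A few compounds are considered here, and "the series" means these few. Any claim that something is new, unique, unknown or untested is made for them only; others in the source may bear on it.

Measured so far in a functional assay on A2780 cells (Homo sapiens) for antiproliferative activity, read by MTT assay, with a stated time of 48 h; on this read-out higher numbers stand for weaker inhibition and lower numbers for stronger inhibition:
compound 1 `C=C(c1ccc2c(c1)C=CC(C)(C)O2)c1ccc(OC)cc1NC(=O)CO`: 110 nM
compound 2 `C=C(c1cc(OC)c(OC)c(OC)c1)c1ccc(OC)cc1NC(=O)CO`: 30 nM
compound 3 `C=C(c1ccc2c(c1)C=CC(C)(C)O2)c1ccc(OC)cc1NC(=O)CN`: 140 nM

Compound 2 gives the lowest of the three numbers in this assay; the difference between its core and the core of compound 1 is not broken down here. Compound 3 differs from compound 1 by amino in place of hydroxy on a saturated chain carbon bound to a carbonyl carbon, and that step, a 1.3-fold higher number from compound 1 to compound 3 (0.10 log units; within the scatter), sits within the scatter. Compound 4 `C=C(c1cc(OC)c(OC)c(OC)c1)c1ccc(OC)cc1NC(=O)CN`, not yet measured, differs from compound 2 by amino in place of hydroxy on a saturated chain carbon bound to a carbonyl carbon, the same change at the same place, so the expected step from compound 2 to compound 4 is a 1.3-fold higher number from compound 2 to compound 4 (0.12 log units; within the scatter), which rests on a 1.3-fold higher number from compound 1 to compound 3 (0.10 log units; within the scatter) being within the scatter. Compound 4 is therefore estimated at 40 nM, with a likely range from 18 nM to 90 nM.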

Compound 4, half-maximal inhibitory concentration: 30 nM
Beside the measured number, compound 4's estimate is 1.3-fold (0.12 log units) above it; low and high end bracket the measured number.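

In this assay, amino in place of hydroxy on a saturated chain carbon bound to a carbonyl carbon gives no change at the digits printed from compound 2 to compound 4 (within the scatter), and the two cores can be set side by side: the same change on two cores in this assay, a 1.3-fold higher number (0.10 log units; within the scatter) from compound 1 to compound 3 and no change at the digits printed (within the scatter) from compound 2 to compound 4, 1.3-fold (0.10 log units) apart, within the scatter of two such steps. The change thus carries from the core of compound 1 to the core of compound 2 without a step beyond the scatter on either core. This rests on two pairs in one assay, so it does not show that the change would stay silent on any other core or in any other read-out.

Still open, from the compounds shown here alone, is whether a dimethylamino group or a carboxylic acid at the same place, or a longer chain in place of aminomethyl, would also stay within the scatter on both cores. Also open, going by these compounds, is whether hydroxy and amino would match on a third core.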